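Swapping phenyl for 4-chlorobenzyl on the ring nitrogen

The source may report more compounds than this note shows. Statements on the series, on what has been measured and on what is new or still open speak of the compounds shown alone.

Of the compounds shown here, three with a shared core have been tested in a functional assay on MCF7 cells (Homo sapiens) for cytotoxicity, read by MTT assay, with a stated time of 24 h, tested at 1.6 ug/mL; on this read-out higher numbers stand for a stronger effect at the one concentration tested and lower numbers for a weaker effect. Compound 1 `CCN1CCN(CC(=O)Nc2ccc(-c3nc(-c4ccccc4)c(-c4ccccc4)n3C)cc2)CC1` gives 14.6%, compound 2 `CN(C)/C=C/N1CCN(CC(=O)Nc2ccc(-c3nc(-c4ccccc4)c(-c4ccccc4)n3C)cc2)CC1` gives 1.9%, and compound 3 `Cn1c(-c2ccc(NC(=O)CN3CCN(c4ccccc4)CC3)cc2)nc(-c2ccccc2)c1-c1ccccc1` gives 21.3%. Compound 3 has the highest of the three numbers, though one of its steps lies within the scatter, a number 6.7 percentage points higher from compound 1 to compound 3 (within the scatter), while the other lies beyond it, a number 19.4 percentage points higher from compound 2 to compound 3 (beyond the scatter). Compound 4 `Cn1c(-c2ccc(NC(=O)CN3CCN(Cc4ccc(Cl)cc4)CC3)cc2)nc(-c2ccccc2)c1-c1ccccc1` differs from compound 3 in one place: 4-chlorobenzyl in place of phenyl on an amine nitrogen in a ring. Going by the values given here, no measured step exchanges phenyl for 4-chlorobenzyl, so the bearing is indirect. The steps that change the group on this same ring nitrogen, a number 12.7 percentage points lower from compound 1 to compound 2 (beyond the scatter), a number 6.7 percentage points higher from compound 1 to compound 3 (within the scatter) and a number 19.4 percentage points higher from compound 2 to compound 3 (beyond the scatter), show that the position can shift the number modestly in either direction. The expectation is therefore a modest step downward or none beyond the scatter, a number 4.3 percentage points lower from compound 3 to compound 4 (within the scatter). Compound 4 is estimated at 17%, with a range from 4% to 32%.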

Compound 4, a percentage reported as activity, at one concentration (the size of the read-out at that concentration, not a potency): 11.8%
The estimate for compound 4 lay 5.2 percentage points above the measured number; low and high end bracket the measured number.
By their numbers in this assay, from the lowest: compounds 2, 4, 1 and 3 (each within the scatter of the next, the first and the last beyond it).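

In this assay, going by these compounds alone, the 4-chlorobenzyl group on the ring nitrogen gives a number 9.5 percentage points lower from compound 3 to compound 4 (within the scatter) and a number 2.8 percentage points lower from compound 1 to compound 4 (within the scatter) and also a number 9.9 percentage points higher from compound 2 to compound 4 (within the scatter) so compound 4 cannot be told apart from any of the earlier compounds, although compound 2 and compound 3 lie beyond the scatter of each other. The position therefore takes a group of 8 heavy atoms with a chlorine in place of the 6 heavy atoms of phenyl without a change that stands clear of the scatter. Nothing measured here gives a reason for these numbers.

A plain benzyl group on the same ring nitrogen would help separate the share of the chlorine from that of the added carbon. A carboxylic acid or a longer alkyl chain at this position remains an open case.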